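The source may report more compounds than this note shows. Statements on the series, on what has been measured and on what is new or still open speak of the compounds shown alone.

Compound 1, `CN1CCC[C@H]1[C@@H]1COc2cc(N)ccc2O1`, and compound 2, `CN1CCC[C@H]1[C@@H]1COc2cc(O)ccc2O1`, share the same core and differ only in one group on an aromatic carbon. In an assay on membranes from Cerebral cortex for displacement of a labelled ligand from Neuronal acetylcholine receptor; alpha4/beta2 (Rattus norvegicus), with a stated time of 5 min (on this read-out higher numbers stand for weaker inhibition and lower numbers for stronger inhibition), compound 1 gives 86000 nM, and compound 2 gives 50000 nM. The step from hydroxy in place of amino is a 1.7-fold lower number from compound 1 to compound 2 (0.24 log units; within the scatter), so the two values cannot be told apart. Compound 2 therefore stands at the lower of the two numbers seen so far, though only within the usual spread of this assay.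

Compound 3, `CN1CCC[C@H]1[C@@H]1COc2cc(-c3ccccc3)ccc2O1`, carries a different change: phenyl in place of hydroxy on an aromatic carbon. Going by the values given here, no measured step involves a phenyl group, so the only comparison at hand, from compound 1 to compound 2, concerns a small polar group and does not directly predict this exchange. With nothing pointing in either direction, the step from compound 2 to compound 3 in this assay is expected to be a 1.4-fold higher number from compound 2 to compound 3 (0.15 log units; within the scatter), giving an estimated value for compound 3 of 70000 nM, with a range from 20000 nM to 300000 nM.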

Compound 3, inhibition constant: 59000 nM
Beside the measured number, compound 3's estimate is 1.2-fold (0.07 log units) above it; the measured number falls inside the stated range.
By their numbers in this assay, from the lowest: compounds 2, 3 and 1 (each within the scatter of the next).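

Replacing hydroxy, with 1 heavy atom, by phenyl, with 6 heavy atoms and an aromatic ring of its own, gives a 1.2-fold higher number from compound 2 to compound 3 (0.07 log units; within the scatter) on this aromatic carbon, and the exchange of amino for phenyl gives a 1.5-fold lower number from compound 1 to compound 3 (0.16 log units; within the scatter) in the same test. Going by these compounds alone, the earlier pair compared only two small groups, whereas these steps show that in this assay even this much larger group, with 0 hydrogen-bond donors and 0 hydrogen-bond acceptors, cannot be told apart from amino or hydroxy. Nothing available explains why these three groups give indistinguishable numbers.

The compounds shown leave open whether any group on this aromatic carbon can shift the number beyond the usual scatter. A carboxylic acid, a methoxy group or a longer alkyl chain there would test this more widely.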